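Silyl ether on the ring hydroxyl in a nitro analogue

The source may report more compounds than this note shows. Statements on the series, on what has been measured and on what is new or still open speak of the compounds shown alone.

Measured so far:
- compound 3 `COc1ccc(C2=C(c3cc(OC)c(OC)c(OC)c3)C(=O)CC2O)cc1`: 3.38 ug/mL
- compound 1 `COc1ccc(C2=C(c3cc(OC)c(OC)c(OC)c3)C(=O)CC2O[SiH2]C(C)(C)C)cc1`: > 100 ug/mL
- compound 2 `COc1ccc(C2=C(c3cc(OC)c(OC)c(OC)c3)CC(O)C2=O)cc1[N+](=O)[O-]`: > 100 ug/mL

In an ADME assay on PA-1 cells (Homo sapiens) for cytotoxicity, read by MTT assay, with a stated time of 72 h (on this read-out lower numbers stand for stronger inhibition and higher numbers for weaker inhibition), compound 3 gives 3.38 ug/mL. Compound 1 sits at a limit of this assay, > 100 ug/mL, not a number. Compound 2 likewise sits at a limit of this assay, > 100 ug/mL, not a number.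

Within the data shown here, the one measured step is a group of 5 heavy atoms (4 carbon, 1 silicon; no ring) in place of a hydrogen atom, on an oxygen on a saturated carbon: it produced an at least 29-fold higher number from compound 3 to compound 1 (1.47 log units; beyond the scatter). With the limit of > 100 ug/mL in this assay, at which 2 of the 3 values shown sit, only the direction and a lower bound of that step are known.

Compound 4 `COc1ccc(C2=C(c3cc(OC)c(OC)c(OC)c3)CC(O[SiH2]C(C)(C)C)C2=O)cc1[N+](=O)[O-]` is the analogue of compound 2 carrying the same kind of change, (a group of 5 heavy atoms (4 carbon, 1 silicon; no ring) in place of a hydrogen atom, on an oxygen on a saturated carbon); the place of the change reads the same in both cases. How the core of compound 2 differs from the core of compound 3 is not broken down here.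

Two things bear on compound 4. First, the same change on compound 3 removed measurable activity in this assay, as the step from compound 3 to compound 1 shows. Second, compound 2, the starting point, already stands at the limit. A step that the limit leaves unreadable from compound 2 to compound 4 is therefore expected, meaning no recovery of activity; the number itself is an estimate. For compound 4 the expected value in this assay is 150 ug/mL, within 50 ug/mL to 500 ug/mL, and most likely it will be reported only as a limit.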

Compound 4, half-maximal inhibitory concentration: > 100 ug/mL
Compound 4: only a limit was reported; the forecaster's own chance of this, stated with the estimate: 85%; the middle value does not contradict the limit.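

Compound 2 and compound 4 both stand at a limit rather than at a number, so no step between them can be read: the limit of > 100 ug/mL in this assay, at which 3 of the 4 values shown sit.

The compounds shown leave open whether the group of 5 heavy atoms in place of a hydrogen atom, on an oxygen on a saturated carbon, changes anything on the core of compound 2.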